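Two Hydroxyphenyl Pyridines and a Furan Isomer Not Yet Tested

A few compounds are considered here, and "the series" means these few. Any claim that something is new, unique, unknown or untested is made for them only; others in the source may bear on it.

Compounds measured in an assay on isolated protein for inhibition of DNA topoisomerase 1 (Homo sapiens), with a stated time of 30 min, tested at 20 uM; a lower number here means a weaker effect, a higher number a stronger effect of the compound at the concentration tested:
- compound 1 `Oc1cccc(-c2cc(-c3ccco3)cc(-c3ccccc3O)n2)c1`: 0%
- compound 2 `Oc1ccc(-c2cc(-c3ccco3)cc(-c3ccccc3O)n2)cc1`: 0%
- compound 3 `Oc1cccc(-c2cc(-c3ccoc3)cc(-c3ccccc3O)n2)c1`: "not determined" (no result reported)

Compound 1 and compound 2 share a core and differ only in one group; the change is 4-hydroxyphenyl in place of 3-hydroxyphenyl on an aromatic carbon. In this assay compound 1 gives 0%, and in this assay compound 2 gives 0%, so the step of no change at the digits printed from compound 1 to compound 2 (within the scatter) is flat.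

Compound 3 carries a different core, and the difference from compound 1 is furan-3-yl in place of furan-2-yl on an aromatic carbon. Going by these compounds, no result was reported for compound 3 in this assay, so its own standing is unknown.

Compound 4 `Oc1ccc(-c2cc(-c3ccoc3)cc(-c3ccccc3O)n2)cc1` has not been measured. Its relation to compound 3 is 4-hydroxyphenyl in place of 3-hydroxyphenyl on an aromatic carbon. Within the data shown here, this is the same kind of change as the one from compound 1 to compound 2, though not the same: in the first pair the place is meta to a furan-2-yl group, whereas here it is meta to a furan-3-yl group. With both compound 1 and compound 2 showing no measurable effect and the step between them flat, a similarly flat outcome is expected for compound 4 in this assay, with the caveat that nothing is known about compound 3 itself. Compound 4 is therefore estimated at 2%, with an expected range from 0% to 15%.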

Compound 4, a percentage reported as inhibition, at one concentration (the size of the read-out at that concentration, not a potency): 3.9%
Estimate against measurement, compound 4: 1.9 percentage points below; low and high end bracket the measured number.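

In this assay the change from furan-2-yl to furan-3-yl, with the 4-hydroxyphenyl group held in place, gives a number 3.9 percentage points higher from compound 2 to compound 4 (within the scatter) and so leaves the read-out much as it was, just as the hydroxyphenyl change gave no change at the digits printed from compound 1 to compound 2 (within the scatter) on the core of compound 1. Among these compounds, this shows only that two single changes stayed within the scatter while every readable value stayed close to nothing, and such flat steps say little about how either change would behave on a compound with a clear effect. For compound 3 the record reads "not determined" (no result reported) in this assay and the step from it to compound 4 cannot be read, so whether the hydroxyphenyl change carries over from one core to the other remains unshown, and nothing available here bears on the reason for these results.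

The compounds shown leave open whether any change to this scaffold can lift the read-out clear of the scatter, given that all of them keep the 2-hydroxyphenyl group. Going by these compounds, it also remains open what an amine or a carboxylic acid in place of one of the hydroxyl groups would do in this assay.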